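A few compounds are considered here, and "the series" means these few. Any claim that something is new, unique, unknown or untested is made for them only; others in the source may bear on it.

Compound 3 `CCCCCCCCCOC(=O)C(CCCCN1C(=O)CCC1=O)N1CCCCC1=O` sits at the limit of the assay: in an ADME assay on SK-N-MC cells (Homo sapiens) for antiproliferative activity, read by MTT assay, with a stated time of 72 h (on this read-out higher numbers stand for weaker inhibition and lower numbers for stronger inhibition), compound 3 gives > 6250 nM, a limit rather than a number. The shorter esters stand the same way. Compound 1 `CCCCCCOC(=O)C(CCCCN1C(=O)CCC1=O)N1CCCCC1=O` gives > 6250 nM, again a limit. Compound 2 `CCCCCCCCOC(=O)C(CCCCN1C(=O)CCC1=O)N1CCCCC1=O` gives > 6250 nM, also a limit. Every value shown thus rests at the limit of > 6250 nM in this assay, at which 3 of the 3 values shown sit, so the steps a step that the two limits leave unreadable from compound 1 to compound 2, a step that the two limits leave unreadable from compound 1 to compound 3 and a step that the two limits leave unreadable from compound 2 to compound 3 cannot be sized. Compound 4 `CCCCCCCCCCCOC(=O)C(CCCCN1C(=O)CCC1=O)N1CCCCC1=O` carries the change (ethyl in place of hydrogen on a saturated chain carbon, nine bonds along the chain from an oxygen next to a carbonyl group), a further lengthening of the ester chain along the same line. Nothing measured reads the direction of chain lengthening here, and each step was unreadable, so no step beyond the scatter is expected. Compound 4 is estimated at 20000 nM, range 6250 nM to 100000 nM, most likely reported again only as a limit. The expected step that the limit leaves unreadable from compound 3 to compound 4 is therefore essentially none.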

Compound 4, half-maximal inhibitory concentration: > 6250 nM
Compound 4: only a limit was reported; the forecaster's own chance of this, stated with the estimate: 85%; the middle value lies beyond the limit too.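

No new step can be read for compound 4 against compound 1, compound 2 or compound 3, because all four rest at the same limit: the limit of > 6250 nM in this assay, at which 4 of the 4 values shown sit. Left open is whether any ester chain shown has a measurable effect in this assay.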